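This account rests on a few compounds, and the source may have more. Where it says the series, first, only, none or still open, it means among the compounds named here.

Measured so far in a functional assay on the whole organism for agonist activity, with Mus musculus as the target; a lower number here means that less compound is needed, a higher number that more compound is needed for the effect:
- compound 1 `COC(=O)N(C)C(C)C#CCN1CCCC1`: 14.2 mg/kg
- compound 2 `COC(=O)N(C)C(C)C#CCn1ccnc1`: 8 mg/kg

Within the data shown here, compound 2, at 8 mg/kg, cannot yet be separated from the only other measured member of the series. Among the measured compounds shown here, the sole comparison, a 1.8-fold lower number from compound 1 to compound 2 (0.25 log units; within the scatter), lies within the scatter.

The next compound is compound 3 `COC(=O)N(C)C(C)C#CCN(C)C`, which has dimethylamino in place of 1H-imidazol-1-yl on a saturated chain carbon bound to a triple-bonded carbon.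

For the measured compounds named here, one measured step bears on this change, since it is the only one made at the same place. That step, a 1.8-fold lower number from compound 1 to compound 2 (0.25 log units; within the scatter), stayed within the scatter, although a ring group was exchanged for another. Going by the values given here, no measured compound carries dimethylamino at this place, so the data give no direction, and a single step is a thin basis for any forecast. In this assay, no shift beyond the scatter is therefore expected. The expected step is a 1.3-fold higher number from compound 2 to compound 3 (0.10 log units; within the scatter). The estimate for compound 3 is 10 mg/kg, with an expected range of 4 mg/kg to 25 mg/kg.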

Compound 3, dose for half-maximal effect: 17.3 mg/kg
Compound 3: the middle estimate sits 1.7-fold (0.24 log units) below what was measured; measured number inside the range.
By their numbers in this assay, from the lowest: compounds 2, 1 and 3 (each within the scatter of the next, the first and the last beyond it).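

In this assay, the place on a saturated chain carbon bound to a triple-bonded carbon now gives its first step beyond the scatter (a 2.2-fold higher number from compound 2 to compound 3 (0.33 log units; beyond the scatter)), a modest one, so 1H-imidazol-1-yl and dimethylamino can be told apart there. The exchange of dimethylamino for pyrrolidin-1-yl stays within the scatter (a 1.2-fold higher number from compound 1 to compound 3 (0.09 log units; within the scatter)), so having a ring at this place does not by itself separate the groups: compound 1 carries a ring yet cannot be told apart from compound 3, which has none, and it also cannot be told apart from compound 2. Among these compounds, the only separated pair is therefore compound 2 and compound 3, with compound 1 overlapping both, and nothing available explains that difference.

Open, going by these compounds, is where a piperidin-1-yl ring, a diethylamino group or a primary amine at this place would fall relative to these three values, and whether any of them would give a step larger than this modest one. Also open, on these data alone, is whether the gap between 1H-imidazol-1-yl and dimethylamino persists when the rest of the shared core is changed.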